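The source may hold more compounds than are shown below. What is called first, only, known or untested is meant among the compounds shown, and "the series" means these compounds.

The three measured compounds share one core and were all read in a functional assay on the whole organism (strain Albino) for inhibition, with Rattus norvegicus as the target, read by paw edema; on this read-out lower numbers stand for an effect already at smaller amounts and higher numbers for an effect only at larger amounts of compound. Compound 1 `Cc1ccc(C(=O)Oc2ccc(C)cc2C(=O)c2ccccc2)cc1` gives 75.5 mg/kg in this assay. Compound 2 `Cc1ccc(C(=O)Oc2ccc(Cl)cc2C(=O)c2ccc(Cl)cc2)cc1` gives 60.5 mg/kg in this assay, and compound 3 `O=C(Oc1ccc(Cl)cc1C(=O)c1ccc(Cl)cc1)c1ccc(Cl)cc1` gives 65.5 mg/kg. On these numbers compound 3 stands second highest of the three, with compound 2 nearest and compound 1 furthest; both of those values lie within the scatter of the value of compound 3, so the three cannot be placed in any order.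

Among the compounds with values here, only one pair of measured compounds differs in a single place, and that step, a 1.1-fold higher number from compound 2 to compound 3 (0.03 log units; within the scatter), stayed within the scatter.

Compound 4 `O=C(Oc1ccc(Br)cc1C(=O)c1ccc(Cl)cc1)c1ccc(Cl)cc1` differs from compound 3 by bromo in place of chloro on an aromatic carbon. Within the data shown here, no measured step exchanges one halogen for another, so nothing measured here bears directly on this change; the one step that is known, the exchange of a methyl for a chloro between compound 2 and compound 3, brought no movement beyond the scatter. Compound 4 is therefore expected to give 65 mg/kg in this assay, with a range from 40 mg/kg to 105 mg/kg. The step this estimate implies, a 1.0-fold lower number from compound 3 to compound 4 (0.00 log units; within the scatter), is expected to remain within the scatter.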

Compound 4, dose for half-maximal effect: 61.5 mg/kg
Compound 4: the middle estimate sits 1.1-fold (0.02 log units) above what was measured; low and high end bracket the measured number.
By their numbers in this assay, from the lowest: compounds 2, 4, 3 and 1 (each within the scatter of the next).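

At this position, an aromatic carbon meta to a group of 9 heavy atoms and para to a large group, the series now holds its first exchange of one halogen for another, and in this assay this exchange gives a 1.1-fold lower number from compound 3 to compound 4 (0.03 log units; within the scatter), so compound 3 and compound 4 cannot be told apart. Bromo and chloro at this place are therefore equivalent within the resolution of this read-out, which the earlier compounds could not show, since their only single-place step, a 1.1-fold higher number from compound 2 to compound 3 (0.03 log units; within the scatter), lies at another place on the shared core and exchanges methyl for chloro. No independent measurement accompanies these compounds that could account for this result.

The compounds shown carry only a halogen or a methyl at this position, so it stays open whether an amine, a carboxylic acid or a longer chain in that place would give a step beyond the scatter. Going by these compounds, it also stays open whether replacing the ester link of the shared core with an amide would move the number further than any single-place exchange seen so far.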